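Cyclopentyl for 4-methylphenyl on the amine of compound 1

The source may hold more compounds than are shown below. What is called first, only, known or untested is meant among the compounds shown, and "the series" means these compounds.

Going by the values given here, compound 1 `Cc1ccc(NC2=CC(=O)c3nc4n(c3C2=O)[C@H]2OC[C@@H](O)[C@H]2OC4)cc1` is the only member of the set with a number in a functional assay on HeLa cells (Homo sapiens) for inhibition, read by sulforhodamine B assay (on this read-out higher numbers stand for weaker inhibition and lower numbers for stronger inhibition), where compound 1 gives 3860 nM. Compound 2 `COc1cccc(NC2=CC(=O)c3c(nc4n3[C@H]3OC[C@@H](O)[C@H]3OC4)C2=O)c1` reaches only a limit of the assay, at > 8000 nM. Compound 3 `O=C1C(NC2CC2)=CC(=O)c2c1nc1n2[C@H]2OC[C@@H](O)[C@H]2OC1` likewise reaches only a limit, at > 16000 nM. Among the compounds with values here, the single measured step, a step that the two limits leave unreadable from compound 2 to compound 3, cannot be sized because both of its ends are limits, the limit of > 8000 nM in this assay, at which 1 of the 3 values shown sits, and (the limit of > 16000 nM in this assay, at which 1 of the 3 values shown sits).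

Compound 4 `O=C1C=C(NC2CCCC2)C(=O)c2c1nc1n2[C@H]2OC[C@@H](O)[C@H]2OC1` differs from compound 1 in one place: cyclopentyl in place of 4-methylphenyl on an amine nitrogen. The step that resembles this change, an aromatic ring replaced by a non-aromatic ring of carbon on the amine nitrogen, is a step that the two limits leave unreadable from compound 2 to compound 3, and its size is unreadable. The compound carrying the non-aromatic ring, compound 3, sits at a limit (the limit of > 16000 nM in this assay, at which 1 of the 3 values shown sits). Weaker inhibition for compound 4 is expected, with a fair chance that only a limit is reported. The step of a 3.1-fold higher number from compound 1 to compound 4 (0.49 log units; beyond the scatter) is estimated as a loss. Compound 4 is expected at 12000 nM, within 4000 nM to 40000 nM.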

Compound 4, half-maximal inhibitory concentration: > 16000 nM
Compound 4: only a limit was reported (the forecaster's own chance of this, stated with the estimate: 50%); middle value at least 1.3-fold (0.12 log units) away from the limit.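

In this assay, going by these compounds alone, replacing the aromatic ring on the amine nitrogen with a non-aromatic ring of carbon now has a readable lower bound: an at least 4.1-fold higher number from compound 1 to compound 4 (0.61 log units; beyond the scatter), whereas the only earlier step of this kind, between compound 2 and compound 3, cannot be read. Compound 4 and compound 3, which both carry a non-aromatic ring of carbon there, stop at the same limit of the assay: the limit of > 16000 nM in this assay, at which 2 of the 4 values shown sit. Compound 2, with 3-methoxyphenyl on the amine nitrogen, also stops at a limit, > 8000 nM, so an aromatic ring there does not by itself give a number.

On these data alone, the full size of the loss at compound 4 remains open, as does how far other aromatic substituents would carry. As far as these compounds go, whether a benzyl group or a longer chain on the amine nitrogen would return a number in this assay also remains open.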